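The source may report more compounds than this note shows. Statements on the series, on what has been measured and on what is new or still open speak of the compounds shown alone.

Compound 1 `Cc1ccc(-c2nc3ccccc3s2)cc1NC(=O)c1cc([N+](=O)[O-])c(N(C)C)cc1Cl`: limit of > 25000 nM
Compound 2 `Cc1ccc(-c2nc3ccccc3s2)cc1NC(=O)c1cc([N+](=O)[O-])c(N2CCCCC2)cc1Cl`: limit of > 25000 nM
Compound 3 `O=C(Nc1cccc(-c2nc3ccccc3s2)c1)c1cc([N+](=O)[O-])ccc1Cl`: limit of > 27000 nM

All three compounds were tested in an ADME assay on HEK293 cells (Homo sapiens) for cytotoxicity, with a stated time of 72 h (a lower number here means that less compound is needed, a higher number that more compound is needed for the effect), and none of them gives an actual number. Going by these compounds, compound 3 stands at a limit, > 27000 nM, so its true position is unknown.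

The change to compound 4 `Cc1ccc(-c2nc3ccccc3s2)cc1NC(=O)c1cc([N+](=O)[O-])ccc1Cl` is small: methyl in place of hydrogen on an aromatic carbon. A methyl takes the place of a hydrogen on an aromatic carbon, para to a 1,3-benzothiazol-2-yl group. Compound 1 and compound 2 also carry this methyl, on cores that differ elsewhere. Compound 1 has a limit of > 25000 nM. Compound 2 has a limit of > 25000 nM.

Among the compounds with values here, the only measured step is a step that the two limits leave unreadable from compound 1 to compound 2. It lies at a different place and offers no size to carry over. No step beyond the usual scatter is therefore expected in this assay, and a further limit is the likeliest report. The estimate means an at least 1.0-fold lower number from compound 3 to compound 4 (0.01 log units; that floor lies within the scatter), an expected change that stays within the scatter. For compound 4 the estimated value is 26000 nM, with an expected range from 12000 nM to 40000 nM.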

Compound 4, half-maximal effective concentration: > 14000 nM
Compound 4: a limit, no number; the forecaster's own chance of this, stated with the estimate: 85%; the middle value is on the limit's open side.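

In this assay compound 4 gives > 14000 nM, which is a limit and not a number. Within the data shown here, compound 1, compound 2 and compound 3 also give only limits, so no step to compound 4 can be read. The compounds shown leave open what concentration any of them needs for the half-maximal effect, and whether the methyl changes it.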